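The source may report more compounds than this note shows. Statements on the series, on what has been measured and on what is new or still open speak of the compounds shown alone.

In a functional assay on PC-3 cells (Homo sapiens) for cytotoxicity, read by sulforhodamine B assay, with a stated time of 48 h (a higher number here means a weaker inhibitor, a lower number a stronger inhibitor), compound 1 `CC(=O)N1N=C(c2ccco2)CC1c1cccc([N+](=O)[O-])c1` gives 20000 nM and compound 2 `O=CCN1N=C(c2ccc3ccccc3c2)CC1c1ccccc1` gives 7400 nM as the lower of the two numbers, a gap that lies beyond the usual scatter. These two compounds differ in more than one place, so their gap cannot be tied to any single change. Compound 3 `O=CCN1N=C(c2ccc3ccccc3c2)CC1c1ccco1` departs from compound 2 in one place only, with furan-2-yl in place of phenyl on a saturated ring carbon. Among the compounds with values here, no measured pair here shows what this exchange does, so in this assay no change beyond the scatter is expected, and neither direction is favoured. The expected step of a 1.1-fold lower number from compound 2 to compound 3 (0.02 log units; within the scatter) is accordingly small. The estimated value for compound 3 is 7000 nM with an expected range of 2500 nM to 20000 nM for its measurement.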

Compound 3, half-maximal inhibitory concentration: 23000 nM
Beside the measured number, compound 3's estimate is 3.3-fold (0.52 log units) below it, outside the stated range (above it).
By their numbers in this assay, from the lowest: compound 2; then compounds 1 and 3 (each within the scatter of the next).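

In this assay, furan-2-yl in place of phenyl on the saturated ring carbon gives a 3.1-fold higher number from compound 2 to compound 3 (0.49 log units; beyond the scatter), so this position does respond to the group it carries, and here phenyl gives the stronger inhibitor of the pair. The exchange replaces a six-membered aromatic ring of carbon only with a five-membered one holding an oxygen and a hydrogen-bond acceptor, and this single step cannot separate ring size from the oxygen. Nothing measured here accounts for the loss.

The compounds shown leave open whether thiophen-2-yl, which keeps the five-membered aromatic ring but carries sulfur in place of the oxygen, would track furan-2-yl or phenyl. They also leave open whether a phenyl bearing a methoxy group would be tolerated at this carbon, and whether the step holds with an acetyl group in place of the formylmethyl group.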